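Swapping the benzyl ring of a cytotoxic aminoquinoline-type compound

The source may report more compounds than this note shows. Statements on the series, on what has been measured and on what is new or still open speak of the compounds shown alone.

So far two compounds have been measured in an ADME assay on HepG2 cells (Homo sapiens) for cytotoxicity, read by luminescence, CellTiter-Glo and ATP content, with a stated time of 72 h; on this read-out lower numbers stand for an effect already at smaller amounts and higher numbers for an effect only at larger amounts of compound. Compound 1 `COc1cccc(CNCCCNc2ccnc3cc(-c4ccc(C(C)(C)C)cc4)ccc23)c1O` gives 690 nM in this assay and compound 2 `COc1cccc(CNCCCNc2ccnc3cc(CCC(C)C)ccc23)c1O` gives 5390 nM. Among the compounds with values here, compound 1 thus has the lowest of the two numbers; the only step measured, a 7.8-fold higher number from compound 1 to compound 2 (0.89 log units; beyond the scatter), concerns a different part of the molecule, the group on the aromatic carbon of the shared core, and says nothing directly about the benzyl end of the chain.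

Compound 3 `COc1ccc(F)cc1CNCCCNc1ccnc2cc(-c3ccc(C(C)(C)C)cc3)ccc12` is not yet measured. It differs from compound 1 by 5-fluoro-2-methoxyphenyl in place of 2-hydroxy-3-methoxyphenyl on a saturated chain carbon bound to an amine nitrogen. Within the data shown here, no measured step touches this position, so the expectation rests on the observation that both compounds measured so far keep the same 2-hydroxy-3-methoxybenzyl group. The change is expected to give a small step, a 1.4-fold higher number from compound 1 to compound 3 (0.16 log units; within the scatter), not clearly beyond the scatter. Compound 3 is therefore estimated at 1000 nM, with a range from 300 nM to 3500 nM.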

Compound 3, half-maximal effective concentration: 620 nM
Beside the measured number, compound 3's estimate is 1.6-fold (0.21 log units) above it; the measured number falls inside the stated range.
By their numbers in this assay, from the lowest: compounds 3 and 1 (each within the scatter of the next); then compound 2.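

Within the data shown here, this is the first measurement at the benzyl end of the chain: in this assay, 5-fluoro-2-methoxyphenyl in place of 2-hydroxy-3-methoxyphenyl gives a 1.1-fold lower number from compound 1 to compound 3 (0.05 log units; within the scatter). The two compounds cannot be told apart here, even though the group that enters has 0 hydrogen-bond donors and the group that leaves has 1, and the entering group carries a fluorine. Nothing available bears on why the two numbers lie so close.

It remains open whether the same exchange would read alike with the isopentyl group of compound 2, as it is shown only with the 4-(tert-butyl)phenyl group. Also open, going by these compounds, is how a benzyl ring carrying an amine or a carboxylic acid would read in this assay.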